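The compounds below may be only part of what the source reports. "The series", "measured", "known", "first", "only" and "open" are said of these compounds alone.

In a functional assay on the whole organism (Gastrocnemius, strain Sprague-Dawley) for inhibition, with Rattus norvegicus as the target (on this read-out higher numbers stand for an effect only at larger amounts of compound and lower numbers for an effect already at smaller amounts), compound 2 (`Nc1ccc(-c2ccc(/C=N/N3C(=O)NC(=O)C3O)o2)cc1`) gives 0.039 umol/kg and compound 1 (`N#Cc1ccc(-c2ccc(/C=N/N3C(=O)NC(=O)C3O)o2)cc1`) gives 0.025 umol/kg so the two stand within the scatter of each other. The change to compound 3 (`O=C1NC(=O)N(/N=C/c2ccc(-c3ccc(F)cc3)o2)C1O`) is fluoro in place of amino on an aromatic carbon para to a large group. Among the measured compounds shown here, the one measured step at this place (a 1.6-fold higher number from compound 1 to compound 2 (0.19 log units; within the scatter)) lies within the scatter, so no step beyond the scatter is expected in this assay for this change. The estimate therefore means only a small step (a 1.0-fold higher number from compound 2 to compound 3 (0.01 log units; within the scatter)) and no firm direction. The estimate for compound 3 is 0.04 umol/kg (expected range: 0.015 umol/kg to 0.11 umol/kg).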

Compound 3, dose for half-maximal effect: 0.091 umol/kg
Compound 3: middle estimate off by 2.3-fold (0.36 log units), on the low side; measured number inside the range.
By their numbers in this assay, from the lowest: compounds 1 and 2 (each within the scatter of the next); then compound 3.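

In this assay, the place para to a large group proves sensitive to the group it carries, which the earlier pair did not show. Fluoro in place of amino gives a 2.3-fold higher number from compound 2 to compound 3 (0.37 log units; beyond the scatter), and fluoro in place of cyano gives a 3.6-fold higher number from compound 1 to compound 3 (0.56 log units; beyond the scatter), while amino and cyano stand within the scatter of each other. From the compounds shown here alone, with a single halogen compared here, it remains open whether chloro or methoxy at this place would stand with fluoro or with amino and cyano. Nothing available bears on why fluoro differs from the other two groups.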